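A Ring Hydroxy on a Compound at the Assay Limit

The source may hold more compounds than are shown below. What is called first, only, known or untested is meant among the compounds shown, and "the series" means these compounds.

In a functional assay on CCRF-CEM cells (Homo sapiens) for antiproliferative activity, with a stated time of 72 h (on this read-out higher numbers stand for an effect only at larger amounts of compound and lower numbers for an effect already at smaller amounts), compound 1 `Cc1cn([C@H]2C[C@H](CF)[C@@H](CO)O2)c(=O)[nH]c1=O` gives > 100 uM, which is a limit and not a number. Compound 2 `Cc1cn([C@H]2C[C@H](CN)[C@@H](CO)O2)c(=O)[nH]c1=O` gives > 100 uM, again a limit. Among the compounds with values here, the only measured step is a step that the two limits leave unreadable from compound 1 to compound 2, so it offers no size to carry forward, and it concerns a different place on the molecule. All the evidence here is the limit of > 100 uM in this assay, at which 2 of the 2 values shown sit.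

Compound 3 `Cc1cn([C@@H]2O[C@H](CO)[C@@H](CF)[C@@H]2O)c(=O)[nH]c1=O` differs from compound 1 by hydroxy in place of hydrogen on a saturated ring carbon. Within the data shown here, no measured step in this assay tests this change, so no definite shift in either direction is expected, and another limit result seems the likeliest outcome. The expected change is a step that the limit leaves unreadable from compound 1 to compound 3. Compound 3 is estimated at 150 uM, with an expected range from 60 uM to 400 uM.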

Compound 3, concentration for half-maximal effect: > 100 uM
Compound 3 gave a limit, no number; the forecaster's own chance of this, stated with the estimate: 85%; the middle value does not contradict the limit.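

In this assay compound 3 gives > 100 uM, a limit and not a number, so no step can be read between compound 1 and compound 3. The compounds shown leave open whether hydroxy in place of hydrogen, or amino in place of fluoro, changes the effect at all, and the only evidence is this: the limit of > 100 uM in this assay, at which 3 of the 3 values shown sit.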